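The source may report more compounds than this note shows. Statements on the series, on what has been measured and on what is new or still open speak of the compounds shown alone.

Measured so far:
- compound 1 `Cc1nc(N)sc1CCCN/C(N)=N/C(=O)NCC(C)CCc1ccccc1` — in a functional assay on membranes from Sf9 cells for agonist activity at histamine H2 receptor (Homo sapiens), read by scintillation counting and GTPgammaS binding, with a stated time of 90 min (on this read-out higher numbers stand for larger maximal responses and lower numbers for smaller maximal responses), compound 1 gives 0.69
- compound 2 `CCCCCCNC(=O)/N=C(\N)NCCCc1sc(N)nc1C` — in this assay compound 2 gives 0.6

Compound 2 has the lowest of these two numbers, yet its gap to compound 1 falls within the usual scatter, so the two cannot be told apart. Compound 3 `Cc1nc(N)sc1CCCN/C(N)=N/C(=O)NCC(C)C1CCCCC1` is not yet measured. Its change from compound 2 is 1-cyclohexylethyl in place of pentyl on a saturated chain carbon bound to an amide-type nitrogen. Within the data shown here, with only two measured compounds, both close together, no real step along this series is known. The expected step a number 0.050 higher from compound 2 to compound 3 (within the scatter) is therefore small, possibly a slight rise, but not clearly beyond the scatter. For compound 3 the estimate is 0.65, within 0.5 to 0.8.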

Compound 3, intrinsic activity: the largest response reached, as a fraction of the reference agonist's: 0.65
Beside the measured number, compound 3's estimate shows no gap at the digits printed; low and high end bracket the measured number.
By their numbers in this assay, from the lowest: compounds 2, 3 and 1 (each within the scatter of the next).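

On a saturated chain carbon bound to an amide-type nitrogen, 1-cyclohexylethyl in place of pentyl gives a step (a number 0.050 higher from compound 2 to compound 3 (within the scatter)), so the two groups cannot be told apart here, although only the second carries a ring. Cyclohexyl in place of phenethyl on a saturated chain carbon bound to two saturated chain carbons likewise gives a step that cannot be told from scatter (a number 0.040 lower from compound 1 to compound 3 (within the scatter)). Nothing available offers an explanation for either result. As far as these compounds go, whether a longer chain or an amine at this position would give a step beyond the scatter remains open.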